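The compounds below may be only part of what the source reports. "The series", "measured", "known", "first", "only" and "open" are said of these compounds alone.

Two compounds of this series have been examined in a functional assay on the whole organism (strain CD1) for inhibition, with Mus musculus as the target, with stated times of 15 min and 20 min, at a dose of 10 mg/kg by the subcutaneous route; on this read-out lower numbers stand for less inhibition and higher numbers for more inhibition at the one dose given (going by the name of the read-out). Compound 1, `N#C/C(=C\c1ccoc1)C(=O)Nc1ccccc1`, carries an anilide and a furan; in this assay compound 1 gives 48%. Compound 2, `N#C/C(=C\c1cc2ccccc2[nH]1)C(=O)O`, bears an indole and a free carboxylic acid; in this assay compound 2 gives 25.8%. Of the two numbers, compound 2 stands lowest, and the gap to compound 1 lies beyond the usual scatter of the measurement.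

Compound 3, `CC(C)CCOC(=O)/C(C#N)=C/c1cc2ccccc2[nH]1`, has not yet been measured. It differs from compound 2 in one place: isopentyl in place of hydrogen on an oxygen next to a carbonyl group. The two compounds share the indole-bearing core; only the ester replaces the acid.

Within the data shown here, no measured pair in this set isolates such a change, so the size of the step has to be guessed from what the two values show. Compound 1, which has no free acid, gives 48%, whereas compound 2 gives 25.8%; on that slim basis the step from acid to ester is expected to be upward and of moderate size, possibly no larger than the scatter. For compound 3 the estimated inhibition is 36%, with a plausible range from 16% to 56%. The expected step, a number 10.2 percentage points higher from compound 2 to compound 3 (beyond the scatter), is therefore modest.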

Compound 3, a percentage reported as inhibition, in the whole organism at one dose (the size of the read-out at that dose, not a potency): 46.6%
The estimate for compound 3 lay 10.6 percentage points below the measured number; the range from low to high includes it.
By their numbers in this assay, from the lowest: compound 2; then compounds 3 and 1 (each within the scatter of the next).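

Among these compounds, putting isopentyl in place of hydrogen on an oxygen next to a carbonyl group gives the first direct reading of this position: in this assay the change from hydroxy to isopentyloxy amounts to a number 20.8 percentage points higher from compound 2 to compound 3 (beyond the scatter). On this shared core, then, the free carboxylic acid is not needed for inhibition at the one dose given, and the ester gives the higher number, though this rests on a single pair. Nothing shown here accounts for the size or direction of the step.

What remains open is whether the step belongs to the isopentyl chain itself or to any ester, as the compounds shown do not say what a methyl group, an ethyl group or a longer chain on this oxygen would give. Also open, going by these compounds, is whether the same change would give a similar step on another core, such as that of compound 1, which differs from compound 2 and compound 3 in more than one place and so offers no direct comparison.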